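Moving the Ring Nitrogen: From Compound 3 to Compound 4

The source may hold more compounds than are shown below. What is called first, only, known or untested is meant among the compounds shown, and "the series" means these compounds.

Measured in a physicochemical assay for lipophilicity, read by HPLC; on this read-out lower numbers stand for lower lipophilicity and higher numbers for higher lipophilicity:
- Compound 1 `COc1ccc(NC[C@@H](O)COc2ccc(N3C[C@H](CNC(C)=O)OC3=O)cc2F)cc1`: 1.15
- Compound 2 `CC(=O)NC[C@H]1CN(c2ccc(OC[C@H](O)CNc3ccccc3)c(F)c2)C(=O)O1`: 0.59
- Compound 3 `CC(=O)NC[C@H]1CN(c2ccc(OC[C@H](O)CNc3ccccn3)c(F)c2)C(=O)O1`: 1.6

Compound 3 stands highest of these three on this assay. The gaps are clear: a number 0.45 log units higher from compound 1 to compound 3 (beyond the scatter), and a number 1.01 log units higher from compound 2 to compound 3 (beyond the scatter).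

Compound 4 `CC(=O)NC[C@H]1CN(c2ccc(OC[C@H](O)CNc3cccnc3)c(F)c2)C(=O)O1` has not yet been measured. It has the same atoms as compound 3, joined differently: pyridin-3-yl in place of pyridin-2-yl on an amine nitrogen. In short, pyridin-3-yl stands in place of pyridin-2-yl on an amine nitrogen.

Within the data shown here, no measured step makes this exchange, so the evidence is indirect. The closest comparison is the phenyl to pyridin-2-yl exchange, a number 1.01 log units higher from compound 2 to compound 3 (beyond the scatter). That large step shows that a single change to this group can move the number a long way, but it does not show where pyridin-3-yl will fall. The methoxy step, a number 0.56 log units lower from compound 1 to compound 2 (beyond the scatter), is modest and concerns the same aromatic group only loosely.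

With compound 3 at the top of the set, a modest fall towards compound 2 seems the likeliest outcome, though no change beyond the scatter remains possible. The expected step is a number 0.50 log units lower from compound 3 to compound 4 (beyond the scatter). For compound 4, the estimated value is 1.1, with an expected range from 0.6 to 1.6.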

Compound 4, partition coefficient: -0.18
For compound 4 the middle estimate is 1.28 log units above the measured one, and the stated range ends above it.
By their numbers in this assay, from the lowest: compound 4; then compound 2; then compound 1; then compound 3.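

Among these compounds, compound 4 shows that this amine nitrogen responds strongly even when the aromatic group keeps the same atoms and the same counts: in this assay, exchanging pyridin-2-yl for pyridin-3-yl gives a number 1.78 log units lower from compound 3 to compound 4 (beyond the scatter), a larger step than any among the earlier compounds. It also shows that replacing a benzene-based group with a pyridine has no single direction here, since the step with pyridin-2-yl is a number 1.01 log units higher from compound 2 to compound 3 (beyond the scatter) while the step with pyridin-3-yl is a number 0.77 log units lower from compound 2 to compound 4 (beyond the scatter), and the comparison with the 4-methoxyphenyl group likewise splits, with a number 0.45 log units higher from compound 1 to compound 3 (beyond the scatter) against a number 1.33 log units lower from compound 1 to compound 4 (beyond the scatter). No measurement offered here accounts for this wide separation of the two pyridine isomers.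

The compounds shown leave open where pyridin-4-yl or pyrimidin-2-yl would fall relative to the two pyridinyl groups on this amine nitrogen. They also leave open whether the same order of pyridin-2-yl over pyridin-3-yl would hold with a methoxy or a methyl group on the pyridine ring.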